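This account rests on a few compounds, and the source may have more. Where it says the series, first, only, none or still open, it means among the compounds named here.

Of the compounds shown here, three have been measured in a functional assay on MDA-MB-231 cells (Homo sapiens) for cytotoxicity, read by MTT assay, with a stated time of 72 h; on this read-out lower numbers stand for stronger inhibition and higher numbers for weaker inhibition. Compound 3 `COc1ccc(Cn2ncc3cc(C(=N)Nc4ccccc4)ncc32)cc1` gives 34700 nM. Compound 1 `COc1ccc(Cn2ncc3cc(C(=N)Nc4ccc(N5CCN(C)CC5)cc4)ncc32)cc1` carries one change relative to it, (4-methylpiperazin-1-yl in place of hydrogen on an aromatic carbon), and in this assay compound 1 gives 5700 nM, so that a 6.1-fold lower number from compound 3 to compound 1 (0.78 log units; beyond the scatter). Compound 2 `N=C(Nc1ccccc1)c1cc2c(-c3ccccc3)n[nH]c2cn1` rests on a different core; the difference between the two cores is not broken down here. In this assay compound 2 gives 11000 nM. Compound 4 `CN1CCN(c2ccc(NC(=N)c3cc4c(-c5ccccc5)n[nH]c4cn3)cc2)CC1` is related to compound 2 by the same change, (4-methylpiperazin-1-yl in place of hydrogen on an aromatic carbon), at the same place. Because the earlier step of a 6.1-fold lower number from compound 3 to compound 1 (0.78 log units; beyond the scatter) lies beyond the usual scatter, compound 4 is expected to show a step of similar size, a 6.1-fold lower number from compound 2 to compound 4 (0.79 log units; beyond the scatter). Compound 4 is therefore estimated at 1800 nM, most likely between 700 nM and 5000 nM.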

Compound 4, half-maximal inhibitory concentration: 15900 nM
Compound 4: middle estimate off by 8.8-fold (0.95 log units), on the low side; the whole stated range lies below it.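

Putting 4-methylpiperazin-1-yl in place of hydrogen on the core of compound 2 gives a 1.4-fold higher number from compound 2 to compound 4 (0.16 log units; within the scatter) in this assay, so the clear drop seen on the other core does not reappear here. The same change therefore does not carry over with the same size from one core to the other: the same change on two cores in this assay, a 6.1-fold lower number (0.78 log units; beyond the scatter) from compound 3 to compound 1 and a 1.4-fold higher number (0.16 log units; within the scatter) from compound 2 to compound 4, 8.8-fold (0.94 log units) apart, beyond the scatter of two such steps. This rests on a single pair of compounds per core and one cell assay, so it shows that the core can matter for this change, but not why, and not how any other group would carry across.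

From the compounds shown here alone, it remains open whether a smaller amine such as dimethylamino, a morpholine ring or a carboxylic acid at the same place would also give different steps on the two cores.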